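From Cyanophenyl to Nitrophenyl on a Shared Core

The source may hold more compounds than are shown below. What is called first, only, known or untested is meant among the compounds shown, and "the series" means these compounds.

Compound 1, `CC(=O)N(C)CC(=O)NCc1cnc2scc(-c3ccc(Br)cc3)n12`, gives 21% in an assay on isolated protein for inhibition of Indoleamine 2,3-dioxygenase 1 (Homo sapiens), with a stated time of 60 min, tested at 1 uM; on this read-out lower numbers stand for less inhibition and higher numbers for more inhibition at the one concentration tested (going by the name of the read-out).
Compound 2, `CN(CC(=O)NCc1cnc2scc(-c3ccc(Br)cc3)n12)C(=O)c1ccc(C#N)cc1`, gives 47% in this assay.

Compound 2 holds the higher of the two numbers. Among the measured compounds shown here, the only measured step, a number 26 percentage points higher from compound 1 to compound 2 (beyond the scatter), is a modest rise beyond the scatter, and it swaps a whole group on the carbonyl carbon rather than one group on the phenyl ring for another. Compound 3, `CN(CC(=O)NCc1cnc2scc(-c3ccc(Br)cc3)n12)C(=O)c1ccc([N+](=O)[O-])cc1`, differs from compound 2 only by nitro in place of cyano on an aromatic carbon. For the measured compounds named here, no measured step speaks to that kind of swap, so the step to compound 3 is expected to be no change at the digits printed from compound 2 to compound 3 (within the scatter), within the scatter. Compound 3 is therefore estimated at 47%, between 27% and 67%.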

Compound 3, a percentage reported as inhibition, at one concentration (the size of the read-out at that concentration, not a potency): 45%
Beside the measured number, compound 3's estimate is 2 percentage points above it; the range from low to high includes it.
By their numbers in this assay, from the lowest: compound 1; then compounds 3 and 2 (each within the scatter of the next).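

Nitro in place of cyano on this aromatic carbon gives a number 2 percentage points lower from compound 2 to compound 3 (within the scatter) in this assay and so leaves the read-out unchanged within the scatter. The gain over the methyl of compound 1 also holds with the 4-nitrophenyl, seen as a number 24 percentage points higher from compound 1 to compound 3 (beyond the scatter) here, so it does not depend on the nitrile alone. Nothing available explains why these two groups read alike. As far as these compounds go, whether an amine or a carboxylic acid on that ring carbon would read the same stays open. So does the effect of moving either group elsewhere on the ring.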